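A few compounds are considered here, and "the series" means these few. Any claim that something is new, unique, unknown or untested is made for them only; others in the source may bear on it.

Of the compounds shown here, three sharing one core have been measured in an assay on cells for agonist activity at ecdysone receptor (Bombyx mori), read by a luciferase reporter, with a stated time of 24 h; on this read-out lower numbers stand for an effect already at smaller amounts and higher numbers for an effect only at larger amounts of compound. Compound 1 `CC(C)(C)N(NC(=O)c1ccccc1)C(=O)c1ccccc1Br` gives 170 nM. Compound 2 `COc1ccccc1C(=O)N(NC(=O)c1ccccc1)C(C)(C)C` gives 525 nM. Compound 3 `CC(C)(C)N(NC(=O)c1cccc(Cl)c1)C(=O)c1ccccc1Cl` gives 155 nM. Among the measured compounds shown here, the single one-place step among them, a 3.1-fold higher number from compound 1 to compound 2 (0.49 log units; beyond the scatter), is a modest rise and concerns methoxy in place of bromo on an aromatic carbon. Compound 3 thus stands at the lowest of the three numbers, within the scatter of compound 1 and beyond the scatter of compound 2.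

Compound 4 `Cc1ccc(C(=O)NN(C(=O)c2ccccc2Cl)C(C)(C)C)cc1C` differs from compound 3 in one place: 3,4-dimethylphenyl in place of 3-chlorophenyl on a carbonyl carbon. For the measured compounds named here, no measured step touches this aromatic ring; the one step recorded sits on the other carbonyl of the core, so it offers only an indirect guide, suggesting that single substituent changes here have moved the number modestly at most. The step from compound 3 is therefore expected to stay within the scatter, a 1.3-fold lower number from compound 3 to compound 4 (0.11 log units; within the scatter). For compound 4 the estimated value in this assay is 120 nM, expected to fall between 40 nM and 400 nM.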

Compound 4, half-maximal effective concentration: 87.1 nM
Beside the measured number, compound 4's estimate is 1.4-fold (0.14 log units) above it; measured number inside the range.
By their numbers in this assay, from the lowest: compounds 4, 3 and 1 (each within the scatter of the next); then compound 2.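

In this assay, the replacement of 3-chlorophenyl by 3,4-dimethylphenyl on a carbonyl carbon attached to the amide-type nitrogen gives a 1.8-fold lower number from compound 3 to compound 4 (0.25 log units; within the scatter). Among the compounds shown here, this is the first step read at this aromatic ring, and it shows that here a ring carrying chlorine and a ring of carbon only, with one more heavy atom, cannot be told apart in this read-out. No available evidence bears on this result.

The compounds shown leave open whether a ring at this place bearing an amine or a carboxylic acid would also stay within the scatter of compound 3. They also leave open whether 3,4-dimethylphenyl would give a similar number with the bromo or methoxy group of compound 1 and compound 2 on the other aromatic ring.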